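Swapping the pyridinyl arm for methoxyphenyl on the triazole

The source may report more compounds than this note shows. Statements on the series, on what has been measured and on what is new or still open speak of the compounds shown alone.

In a functional assay on MCF7 cells (Homo sapiens) for cytotoxicity, read by MTT assay, with a stated time of 4 days (a lower number here means a stronger inhibitor, a higher number a weaker inhibitor), compound 1 `Cc1ccc(S(=O)(=O)Oc2ccc3c(c2C)[C@H](Cn2cc(-c4ccccn4)nn2)[C@@]24CC(=O)[C@@](C)(CC[C@@H]32)C4)cc1` gives a result that is only a limit of the assay, > 20000 nM.
In this assay compound 2 `Cc1c(O)ccc2c1[C@H](Cn1cc(-c3ccccn3)nn1)[C@@]13CC(=O)[C@@](C)(CC[C@@H]21)C3` likewise gives only a limit, > 20000 nM.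
In this assay compound 3 `C=C1C[C@]23C[C@@]1(O)CC[C@H]2c1cc(Br)c(O)c(C)c1[C@@H]3Cn1cc(-c2ccccn2)nn1` also gives only a limit, > 20000 nM.

Compound 2 therefore stands at the limit at which every value here sits (the limit of > 20000 nM in this assay, at which 3 of the 3 values shown sit), and nothing on these numbers separates it from compound 1 or compound 3. Compound 4 `COc1ccc(-c2cn(C[C@H]3c4c(ccc(O)c4C)[C@@H]4CC[C@@]5(C)C[C@]43CC5=O)nn2)cc1` differs from compound 2 by a single change, (4-methoxyphenyl in place of pyridin-2-yl on an aromatic carbon). Among the compounds with values here, only one measured step involves a single change, a step that the two limits leave unreadable from compound 1 to compound 2, and both of its ends are limits, so its size cannot be read; it also concerns the group on an oxygen on an aromatic ring rather than the triazole arm, so it offers no guide here. Compound 3 keeps the pyridin-2-yl arm and sits at the same limit. With no readable step available, the expectation is for no step beyond the scatter, a step that the limit leaves unreadable from compound 2 to compound 4. Compound 4 is estimated at 25000 nM, within a range from 8000 nM to 80000 nM, and will most likely again be reported only as a limit.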

Compound 4, half-maximal inhibitory concentration: > 20000 nM
Compound 4 gave a limit, no number; the forecaster's own chance of this, stated with the estimate: 70%; the middle value is on the limit's open side.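

Compound 2 and compound 4 both give only a limit of the assay rather than a number in this assay, so no size can be read for the step between them: the limit of > 20000 nM in this assay, at which 4 of the 4 values shown sit.

The compounds shown leave open whether pyridin-2-yl and 4-methoxyphenyl differ at all, and what on the shared core would bring a readable number in this assay.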